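Replacing a benzyl group on the ring amine of a thiophene amide

The compounds below may be only part of what the source reports. "The series", "measured", "known", "first", "only" and "open" are said of these compounds alone.

Two measured compounds share a core in which a carboxamide-bearing ring is fused to a six-membered non-aromatic ring with one nitrogen. Compound 1, `Cc1ccccc1CN1CCc2c(sc(NC(=O)c3ccccc3Cl)c2C(N)=O)C1`, carries a 2-methylbenzyl group on that ring nitrogen. From the compounds shown here alone, in a functional assay on HL-60 cells (Homo sapiens) for antiproliferative activity, with a stated time of 24 h (a lower number here means a stronger inhibitor, a higher number a weaker inhibitor), compound 1 gives only a limit, > 50000 nM, so its true potency is unknown beyond that. Compound 2, `NC(=O)c1c(NC(=O)c2cccc([N+](=O)[O-])c2)sc2c1CCN(Cc1ccc(Cl)cc1Cl)C2`, differs from compound 1 in more than one place. In this assay compound 2 gives 19800 nM. With the limit of > 50000 nM in this assay, at which 1 of the 2 values shown sits, as the only statement about compound 1, it stands at the weakest end of what is shown.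

Compound 3, `NC(=O)c1c(NC(=O)c2ccccc2Cl)sc2c1CCN(C(=S)Nc1ccccc1I)C2`, keeps the amide side of compound 1 and changes the ring nitrogen: a group of 10 heavy atoms (7 carbon, 1 nitrogen, 1 sulfur, 1 iodine; one six-membered aromatic ring of carbon only) in place of a group of 8 heavy atoms (8 carbon; one six-membered aromatic ring of carbon only), on an amine nitrogen in a ring. Within the data shown here, no measured pair isolates a change of this kind, so the step from compound 1 to compound 3 cannot be read from the data. Both shown values sit in the weak range, and the expectation for compound 3 is a weak inhibitor as well, with an estimated step of an at least 1.6-fold lower number from compound 1 to compound 3 (0.22 log units; that floor lies within the scatter). Compound 3 is therefore expected near 30000 nM, within 8000 nM to 100000 nM.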

Compound 3, half-maximal inhibitory concentration: 4430 nM
The estimate for compound 3 lay 6.8-fold (0.83 log units) above the measured number, and the stated range ends above it.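

With the amide side held fixed, the amine nitrogen in the ring proves to be a position that matters in this assay: putting the group carrying sulfur and iodine in place of 2-methylbenzyl gives an at least 11-fold lower number from compound 1 to compound 3 (1.05 log units; beyond the scatter). Compound 1 and compound 2 differ in more than one place, so neither could show what a change at this nitrogen alone does, whereas this pair shows that a benzyl group is not required there for a measurable effect in this cell assay. The real size of the step stays unknown, and the printed figure is only a floor, because compound 1 is known solely through a limit: the limit of > 50000 nM in this assay, at which 1 of the 3 values shown sits.

The entering group brings sulfur, iodine, a double bond outside the aromatic ring, and a hydrogen-bond donor and acceptor all at once, so the compounds shown cannot tell which of these features goes with the lower number. From the compounds shown here alone, it remains open whether a urea with oxygen in place of the sulfur, or the same group with a plain phenyl ring lacking the iodine, would give a similar value.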